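The source may hold more compounds than are shown below. What is called first, only, known or untested is meant among the compounds shown, and "the series" means these compounds.

Compound 1 `COc1cc(-c2cc(/C=C/C(=O)c3ccc(N)cc3)[nH]n2)cc(OC)c1OC` is the reference point of this small set. Among the measured compounds shown here, in a functional assay on Malme-3M cells (Homo sapiens) for inhibition, read by sulforhodamine B assay, with a stated time of 48 h (a higher number here means that more compound is tolerated, a lower number that less compound is tolerated), compound 1 gives 14400 nM, the lowest of the two numbers known so far. For the measured compounds named here, its only measured neighbour is compound 2 `COc1ccc(-c2cc(/C=C/C(=O)c3ccc(N)cc3)[nH]n2)cc1OC`, which in this assay gives 59200 nM; the step of a 4.1-fold higher number from compound 1 to compound 2 (0.61 log units; beyond the scatter) is the single comparison available, and it concerns a methoxy group on the shared core rather than the ring on the carbonyl carbon.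

Compound 3 `COc1cc(-c2cc(/C=C/C(=O)c3ccc(F)c(F)c3)[nH]n2)cc(OC)c1OC` is not yet measured. Its difference from compound 1 is 3,4-difluorophenyl in place of 4-aminophenyl on a carbonyl carbon. Going by the values given here, no measured step touches this part of the molecule, so nothing in the data shows whether exchanging the 4-aminophenyl for the 3,4-difluorophenyl moves the number up or down, or by how much. Among the compounds with values here, the one known step, at a different place, was modest, and without a closer guide the expectation for compound 3 is a number not far from that of compound 1, with wide uncertainty. Compound 3 is estimated at 25000 nM in this assay, within a range of 6000 nM to 100000 nM. That estimate corresponds to an expected step of a 1.7-fold higher number from compound 1 to compound 3 (0.24 log units; within the scatter).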

Compound 3, concentration lethal to 50% of the cells: > 100000 nM
Compound 3 gave a limit, no number; the forecaster's own chance of this, stated with the estimate: 10%; at least 4.0-fold (0.60 log units) between middle value and limit.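

The ring on the carbonyl carbon, which the earlier comparison left untouched, proves to be a place where a change registers in this assay: 3,4-difluorophenyl in place of 4-aminophenyl gives an at least 6.9-fold higher number from compound 1 to compound 3 (0.84 log units; beyond the scatter). The methoxy change gives a 4.1-fold higher number from compound 1 to compound 2 (0.61 log units; beyond the scatter), so both single changes shown, at two different places on compound 1, move the number in the same direction, and no change shown lowers it. Compound 3 gives a limit rather than a number, so the true size of its step stays unknown and only its direction can be read: the limit of > 100000 nM in this assay, at which 1 of the 3 values shown sits.

The compounds shown do not separate the loss of the amino group from the arrival of the fluorine atoms, as both occur in a single step. They also leave open how a plain phenyl, a 4-hydroxyphenyl or a 4-fluorophenyl on the carbonyl carbon would read in this assay, and whether a group such as a 4-(dimethylamino)phenyl would keep the number of compound 1.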